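The source may hold more compounds than are shown below. What is called first, only, known or untested is meant among the compounds shown, and "the series" means these compounds.

Compound 1 `CCOC(=O)C(C)(C)ON1C(=O)c2ccccc2C1=O`: 95%
Compound 2 `CCOC(=O)C(Cc1ccccc1)ON1C(=O)c2ccccc2C1=O`: 70%

Both compounds were tested in a functional assay on the whole organism for inhibition, with Lepidium sativum as the target, tested at 100 ppm; on this read-out higher numbers stand for more inhibition of growth at the one concentration tested and lower numbers for less inhibition of growth. Compound 1 gives 95% there. Among the measured compounds shown here, compound 2 gives 70%, the lower of the two numbers; its only neighbour, compound 1, stands higher by a gap beyond the usual scatter. Compound 3 `CCOC(=O)C(CC)ON1C(=O)c2ccccc2C1=O` has not been measured yet. It differs from compound 2 in one place: methyl in place of phenyl on a saturated chain carbon, two bonds along the chain from a carbonyl carbon and an oxygen on an unsaturated carbon. Compound 3 therefore carries a smaller group on that saturated chain carbon than compound 2 does, and compound 1, which carries only methyl there, gave the higher number. For the measured compounds named here, no step between measured compounds of this same kind is available, so the expectation rests on those two values alone. A moderate rise in this assay is expected for compound 3, as a step of a number 15 percentage points higher from compound 2 to compound 3 (beyond the scatter). Compound 3 is estimated at 85%, with a range from 65% to 98%.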

Compound 3, percent growth inhibition at one concentration: 94%
For compound 3 the middle estimate is 9 percentage points below the measured one; the measured number falls inside the stated range.
By their numbers in this assay, from the lowest: compound 2; then compounds 3 and 1 (each within the scatter of the next).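

In this assay, putting methyl in place of phenyl on this saturated chain carbon gives a number 24 percentage points higher from compound 2 to compound 3 (beyond the scatter), so at the one concentration tested, this series does not need the phenyl at this position for growth inhibition. Among the compounds shown here, compound 2 and compound 3 are the first pair here that differ in one place only, which lets this change be read directly, whereas compound 1 and compound 2 differ by more than that single swap. Nothing available explains why the compound with the smaller group gives the higher number.

Going by these compounds, what a longer chain such as butyl, or an amine, would do on this same carbon remains open. So does whether this single step would hold on any other core.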